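Ester series: hydrogen for chloro on compound 1

The source may hold more compounds than are shown below. What is called first, only, known or untested is meant among the compounds shown, and "the series" means these compounds.

Measured in a physicochemical assay for lipophilicity, measured as octanol-water partition; on this read-out higher numbers stand for higher lipophilicity and lower numbers for lower lipophilicity:
compound 1 `CC(C)[C@@H]1CC[C@@H](C)C[C@H]1OC(=O)c1cccc(Cl)c1` — 5.34
compound 2 `CC(Cl)C(=O)O[C@@H]1C[C@H](C)CC[C@H]1C(C)C` — 4.04
compound 3 `CC(C)[C@@H]1CC[C@@H](C)C[C@H]1OC(=O)c1ccccc1Br` — 5.61

Of the compounds shown here, three have a number in this assay so far. Compound 1 stands second of the three. Its nearest neighbour is compound 3, whose number lies within the scatter of that of compound 1, so no order between these two can be read from the data. The furthest is compound 2, whose number lies well beyond the scatter below that of compound 1; it is also the only one of the three without an aromatic ring on the ester side.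

The next compound, compound 4 `CC(C)[C@@H]1CC[C@@H](C)C[C@H]1OC(=O)c1ccccc1`, differs from compound 1 in one place: hydrogen in place of chloro on an aromatic carbon. Going by the values given here, no step between two measured compounds covers this change, so its size cannot be taken from a measured pair. On general experience with this kind of exchange, a drop in this assay beyond the scatter is expected, estimated as a number 0.69 log units lower from compound 1 to compound 4 (beyond the scatter). For compound 4 the estimated value in this assay is 4.65, with a range from 4.3 to 5.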

Compound 4, partition coefficient: 4.82
Compound 4: middle estimate off by 0.17 log units, on the low side, and the stated range covers the measured number.
By their numbers in this assay, from the lowest: compound 2; then compound 4; then compounds 1 and 3 (each within the scatter of the next).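

In this assay the removal of a ring halogen now has a measured size: hydrogen in place of chloro on an aromatic carbon, meta to a large group, gives a number 0.52 log units lower from compound 1 to compound 4 (beyond the scatter), and removing the bromo group from the aromatic ring gives a number 0.79 log units lower from compound 3 to compound 4 (beyond the scatter). Both halogen-bearing compounds therefore stand apart from the compound carrying hydrogen, whereas compound 1 and compound 3 remain within the scatter of each other, so the data give no order between chloro and bromo. Phenyl in place of 1-chloroethyl on a carbonyl carbon gives a number 0.78 log units higher from compound 2 to compound 4 (beyond the scatter), which shows that the separation of compound 2 from the aromatic esters persists without a halogen on the aromatic ring.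

No evidence among the data shown explains the size of any of these steps. Open, on these data alone, is whether the chloro step would keep its size at another place on the aromatic ring, and how a methoxy group or an amine at the same place would compare with chloro and hydrogen.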